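Second chloro on the core of compound 1

The source may report more compounds than this note shows. Statements on the series, on what has been measured and on what is new or still open speak of the compounds shown alone.

Compound 1 `ClCc1cccc(Cn2cnc3ncnc(Cl)c32)c1` and compound 2 `ClCc1cccc(Cn2cnc3c(Cl)ncnc32)c1` share their atoms but are joined differently; the difference between the two cores is not broken down here. In a functional assay on M14 cells (Homo sapiens) for cytotoxicity, read by sulforhodamine B assay, with a stated time of 48 h (on this read-out higher numbers stand for weaker inhibition of growth and lower numbers for stronger inhibition of growth), compound 1 gives 14500 nM, the highest number of the three measured, while compound 2 gives 3310 nM. Compound 3 `ClCc1cccc(Cn2cnc3c(Cl)nc(Cl)nc32)c1` carries chloro in place of hydrogen on an aromatic carbon and gives 3380 nM; the step of a 1.0-fold higher number from compound 2 to compound 3 (0.01 log units; within the scatter). Compound 4 `ClCc1cccc(Cn2cnc3nc(Cl)nc(Cl)c32)c1` carries the same change on the core of compound 1, (chloro in place of hydrogen on an aromatic carbon), the place being described in identical words. Resting on a 1.0-fold higher number from compound 2 to compound 3 (0.01 log units; within the scatter), the step from compound 1 to compound 4 is expected to be no change at the digits printed from compound 1 to compound 4 (within the scatter). Compound 4 is therefore estimated at 14500 nM, with a range from 7000 nM to 30000 nM.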

Compound 4, concentration for total growth inhibition: 2630 nM
Estimate against measurement, compound 4: 5.5-fold (0.74 log units) above; the whole stated range lies above it.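

In this assay chloro in place of hydrogen on an aromatic carbon gives a 5.5-fold lower number from compound 1 to compound 4 (0.74 log units; beyond the scatter) on the core of compound 1. This rests on a single pair for each core, and it does not show what in the cores separates the two steps or how the change would run on a further core. The change does not carry over with one size from one core to the other in this series: the same change on two cores in this assay, a 1.0-fold higher number (0.01 log units; within the scatter) from compound 2 to compound 3 and a 5.5-fold lower number (0.74 log units; beyond the scatter) from compound 1 to compound 4, 5.6-fold (0.75 log units) apart, beyond the scatter of two such steps.

The compounds shown leave open whether an amine or a methoxy group entering at the same place would give a step that also differs between the two cores.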